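The source may hold more compounds than are shown below. What is called first, only, known or untested is meant among the compounds shown, and "the series" means these compounds.

Measured so far in a functional assay on L929 cells (Mus musculus) for antiproliferative activity, read by MTT assay; on this read-out lower numbers stand for stronger inhibition and higher numbers for weaker inhibition:
- Compound 1 `C[C@@H]1[C@@H]2[C@@H](CC(=O)[C@H]2C)C[C@H]1O[Si](c1ccccc1)(c1ccccc1)C(C)(C)C`: 14800 nM
- Compound 2 `C=CC[C@@H]1[C@H]2[C@H](C)C=C[C@H]2C[C@H]1O[Si](c1ccccc1)(c1ccccc1)C(C)(C)C`: 7200 nM

Compound 1 has the higher number of the two, and the gap to compound 2 lies beyond the usual scatter. Compound 3 `CC(C)=CC[C@@H]1C(=O)C[C@H]2C[C@@H](O[Si](c3ccccc3)(c3ccccc3)C(C)(C)C)[C@H](C)[C@H]21` has not yet been measured. It differs from compound 1 by 2-methylprop-1-en-1-yl in place of hydrogen on a saturated chain carbon bound to a saturated ring carbon, which places 2-methylprop-1-en-1-yl in place of hydrogen on a saturated chain carbon bound to a saturated ring carbon. In this assay the expected change is a 2.1-fold lower number from compound 1 to compound 3 (0.33 log units; beyond the scatter), a step toward a lower number. Within the data shown here, this expectation rests on compound 2, which gives 7200 nM, though no measured step covers this change. For compound 3 the estimated value is 7000 nM, with an expected range of 2000 nM to 20000 nM.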

Compound 3, half-maximal inhibitory concentration: 5600 nM
Compound 3: the middle estimate sits 1.3-fold (0.10 log units) above what was measured; the measured number falls inside the stated range.
By their numbers in this assay, from the lowest: compounds 3 and 2 (each within the scatter of the next); then compound 1.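

In this assay the core of compound 1 accepts 2-methylprop-1-en-1-yl in place of hydrogen on a saturated chain carbon bound to a saturated ring carbon, with a 2.6-fold lower number from compound 1 to compound 3 (0.42 log units; beyond the scatter) as a modest gain. Read one bond further out, methyl becomes 3-methylbut-2-en-1-yl, so at this position the longer chain brings no loss. Nothing available explains this gain. Still open, from the compounds shown here alone, is whether a saturated chain such as 3-methylbutyl would do the same, and how an amine or a carboxylic acid would fare here.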